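This account rests on a few compounds, and the source may have more. Where it says the series, first, only, none or still open, it means among the compounds named here.

Measured compounds:
Compound 1, `CCOC(=O)C1=C(N/N=C(/Br)c2ccccc2)Nc2[nH]nc(C)c2C1c1ccc(N(C)C)cc1`, gives 72000 nM in a functional assay on HepG2 cells (Homo sapiens) for inhibition, read by MTT assay, with a stated time of 48 h; on this read-out higher numbers stand for weaker inhibition and lower numbers for stronger inhibition.
Compound 2, `CCOC(=O)C1=C(N/C=N/c2nnc(S(N)(=O)=O)s2)Nc2[nH]nc(C)c2C1c1ccc(N(C)C)cc1`, gives 38100 nM in this assay.
Compound 3, `CCOC(=O)C1=C(N/N=C(\c2ccc([N+](=O)[O-])cc2)N2CCN(c3ccc(F)cc3)CC2)Nc2[nH]nc(C)c2C1c1ccc(N(C)C)cc1`, gives 90200 nM in this assay.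

Compound 2 shows the lowest of the three numbers in this assay. Its nearest neighbour is compound 1, and compound 3 lies further off, beyond the scatter. The piece follows the step from compound 2 to compound 4, `CCOC(=O)C1=C(N/N=C(/Cl)C#N)Nc2[nH]nc(C)c2C1c1ccc(N(C)C)cc1`. The change is a group of 5 heavy atoms (2 carbon, 2 nitrogen, 1 chlorine; no ring) in place of a group of 11 heavy atoms (3 carbon, 4 nitrogen, 2 oxygen, 2 sulfur; one five-membered aromatic ring with 3 hetero atoms), on an amine nitrogen.

Among the measured compounds shown here, one measured step bears on this position: the same amine nitrogen carries the group exchanged in a 1.9-fold lower number from compound 1 to compound 2 (0.28 log units; within the scatter), and that step stayed within the scatter. Compound 3, which also varies at this position, gives a number somewhat higher than compound 2. Replacing the group of 11 heavy atoms with the group of 5 heavy atoms is therefore expected to give a number close to that of compound 1 or compound 2, with no step beyond the scatter predicted with confidence in this assay, though a modest rise is thought somewhat more likely than a fall. The expected step is a 1.4-fold higher number from compound 2 to compound 4 (0.16 log units; within the scatter). Compound 4 is estimated at 55000 nM, in a range from 20000 nM to 150000 nM.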

Compound 4, half-maximal inhibitory concentration: 23600 nM
Estimate against measurement, compound 4: 2.3-fold (0.37 log units) above; measured number inside the range.
By their numbers in this assay, from the lowest: compounds 4, 2, 1 and 3 (each within the scatter of the next, the first and the last beyond it).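

With a group of 5 heavy atoms with no ring on this amine nitrogen, compound 4 stays within the scatter of compound 2 in this assay, at a 1.6-fold lower number from compound 2 to compound 4 (0.21 log units; within the scatter), so at this position an aromatic ring in the group is not needed to keep the number in that range. The same group also gives a 3.1-fold lower number from compound 1 to compound 4 (0.48 log units; beyond the scatter), a modest step beyond the scatter, which shows that exchanging one group for another on this nitrogen can move the number measurably even when the incoming group is the smaller one. Nothing measured here accounts for either step.

The compounds shown leave open whether the chlorine or the nitrile of this group matters more, and a version carrying only one of them would separate the two. They also leave open how a carboxylic acid or a short alkyl chain would behave on the same nitrogen.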